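The source may hold more compounds than are shown below. What is called first, only, known or untested is meant among the compounds shown, and "the series" means these compounds.

Measured compounds:
compound 1, `CCOC(=O)c1cccc(-c2ccc(OC)cc2)c1`, giving 77%
compound 2, `CCOC(=O)c1cccc(-c2ccc(OCC)nc2)c1`, giving 68%

In an assay on COS-7 cells for inhibition of patatin-like phospholipase domain-containing protein 2 (Mus musculus), tested at 200 uM (a higher number here means more inhibition at the concentration tested (going by the name of the read-out), a lower number less inhibition), compound 1 gives 77%, the highest of the two numbers recorded. Its nearest neighbour is compound 2, which in this assay gives 68%, a gap that lies within the scatter of the assay, so the two compounds cannot be told apart on these numbers. Within the data shown here, no step between two measured compounds that differ in a single place is available.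

Compound 3, `CCOC(=O)c1cccc(-c2ccc([N+](=O)[O-])cc2)c1`, has not yet been measured in this assay. It differs from compound 1 in one place: nitro in place of methoxy on an aromatic carbon. Among the measured compounds shown here, with no measured step of this kind to lean on, the expected step of a number 12 percentage points lower from compound 1 to compound 3 (beyond the scatter) is small, roughly downward but not clearly beyond the scatter. Compound 3 is accordingly estimated to give 65% in this assay, with a range from 35% to 90%.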

Compound 3, a percentage reported as inhibition, at one concentration (the size of the read-out at that concentration, not a potency): 63%
Compound 3: middle estimate off by 2 percentage points, on the high side, and the stated range covers the measured number.
By their numbers in this assay, from the lowest: compounds 3, 2 and 1 (each within the scatter of the next, the first and the last beyond it).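

In this assay, among these compounds, this is the first comparison of two compounds that differ in a single place. Putting nitro in place of methoxy on the aromatic carbon para to a large group gives a number 14 percentage points lower from compound 1 to compound 3 (beyond the scatter), so a change at this position can be read beyond the scatter. The step is modest, and compound 3 still gives 63% at the concentration tested, so inhibition is reduced at this position but not lost with this replacement. Nothing at hand bears on what lies behind the step.

A single replacement cannot show whether the lower number follows from the arrival of nitro or the departure of methoxy. From the compounds shown here alone, what an amine or a carboxylic acid would give at this same place remains open, as does whether the step would be the same on a different core.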